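This account rests on a few compounds, and the source may have more. Where it says the series, first, only, none or still open, it means among the compounds named here.

Of the compounds shown here, three have been measured so far. Compound 1 `O=C(O)Cc1sc(C(c2ccccc2)c2ccccc2)nc1-c1ccccc1` gives 570 nM in an in vitro assay on HEK385-7 cells for displacement of a labelled ligand from prostaglandin D2 receptor 2 (Homo sapiens); on this read-out higher numbers stand for weaker inhibition and lower numbers for stronger inhibition. Among the compounds with values here, compound 3 `O=C(O)Cc1sc(C(c2ccccc2)c2ccccc2)nc1-c1ccc(F)c(F)c1` gives 4.1 nM in this assay, and the change from compound 1, a 140-fold lower number from compound 1 to compound 3 (2.14 log units; beyond the scatter), is the only step among the measured pairs. Compound 2 `O=C(O)Cc1sc(C(c2ccc(F)cc2)c2ccc(F)cc2)nc1-c1ccnc(N2CCC2)c1` gives 660 nM in this assay, the highest of the three numbers shown, although its gap to compound 1 lies within the scatter, while its gap to compound 3 lies well beyond it.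

Compound 4 `O=C(O)Cc1sc(C(c2ccc(F)cc2)c2ccc(F)cc2)nc1-c1ccncc1` differs from compound 2 only in one place: hydrogen in place of azetidin-1-yl on an aromatic carbon. Within the data shown here, the change from compound 1 to compound 3 sits at a different place and swaps a different group, so no measured step bears directly on this one. With nothing in the measured pairs to point either way, the step of a 1.4-fold higher number from compound 2 to compound 4 (0.13 log units; within the scatter) is expected to stay within the scatter, with a wide allowance for the unknown. Compound 4 is therefore estimated at 900 nM in this assay, with a range from 250 nM to 3500 nM.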

Compound 4, half-maximal inhibitory concentration: 5.3 nM
Estimate against measurement, compound 4: 170-fold (2.23 log units) above; measured number outside the range, below it.
By their numbers in this assay, from the lowest: compounds 3 and 4 (each within the scatter of the next); then compounds 1 and 2 (each within the scatter of the next).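

In this assay, hydrogen in place of azetidin-1-yl on an aromatic carbon next to the ring nitrogen gives a 120-fold lower number from compound 2 to compound 4 (2.10 log units; beyond the scatter) and lies beyond the scatter. Within the data shown here, the only earlier step, a 140-fold lower number from compound 1 to compound 3 (2.14 log units; beyond the scatter), concerned a different group at a different place, so this is the first sign that this position on the pyridin-4-yl group matters. Nothing available here accounts for the size of the step.

On these data alone, whether a small group at the same place, such as methyl or a dimethylamino group, would stay close to compound 4 or move towards compound 2 remains open. Also open, as far as these compounds go, is how pyridin-4-yl compares with phenyl, as compound 4 differs from compound 1 in more than one place.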